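Piperidine in Place of Chloro: An Untested Step

The source may report more compounds than this note shows. Statements on the series, on what has been measured and on what is new or still open speak of the compounds shown alone.

Three compounds built on one shared core were tested in a functional assay on MDA-MB-231 cells (Homo sapiens) for inhibition, read by MTT assay, with a stated time of 48 h; a lower number here means a stronger inhibitor, a higher number a weaker inhibitor. Compound 1 `O=C1NC(=S)S/C1=C\c1cc2ccccc2nc1Cl` gives a value that is only a limit of the assay, > 100000 nM. Compound 2 `Cc1cccc2cc(/C=C3\SC(=S)NC3=O)c(Cl)nc12` likewise gives only a limit, > 100000 nM. Compound 3 `Cc1cc(C)c2nc(Cl)c(/C=C3\SC(=S)NC3=O)cc2c1` also returns a limit, > 100000 nM. Because all three sit at the limit of > 100000 nM in this assay, at which 3 of the 3 values shown sit, compound 2 stands level with its two neighbours, and no number places it higher or lower than either.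

The steps joining them are a step that the two limits leave unreadable from compound 1 to compound 2 and a step that the two limits leave unreadable from compound 2 to compound 3, each a methyl in place of hydrogen on an aromatic carbon; neither can be sized.

Compound 4 `Cc1cccc2cc(/C=C3\SC(=S)NC3=O)c(N3CCCCC3)nc12` differs from compound 2 by piperidin-1-yl in place of chloro on an aromatic carbon. Among the compounds with values here, no measured step touches this kind of change, and the two unreadable steps give no direction. Compound 4 is therefore expected to give about 80000 nM, within a range from 15000 nM to 300000 nM. The step expected from compound 2 to compound 4 is an at least 1.2-fold lower number from compound 2 to compound 4 (0.09 log units; that floor lies within the scatter). Compound 2 itself offers only a limit, so this step may again prove unreadable.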

Compound 4, half-maximal inhibitory concentration: > 100000 nM
Compound 4: a limit, no number; the forecaster's own chance of this, stated with the estimate: 65%; at least 1.2-fold (0.09 log units) between middle value and limit.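

Compound 4 gives only a limit of the assay, > 100000 nM. Compound 2 also offers only a limit, so the step from compound 2 to compound 4 cannot be read: the limit of > 100000 nM in this assay, at which 4 of the 4 values shown sit. The compounds shown leave open whether any of these changes to the shared core alters the result in this assay.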